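A few compounds are considered here, and "the series" means these few. Any claim that something is new, unique, unknown or untested is made for them only; others in the source may bear on it.

The series shares one core. Compound 1 `O=C(COc1ccccc1)Nc1nc(-c2ccc(Br)cc2)cs1` carries bromo, and in a functional assay on A549 cells (Homo sapiens) for cytotoxicity, read by trypan blue exclusion, with a stated time of 48 h (on this read-out lower numbers stand for stronger inhibition and higher numbers for weaker inhibition), compound 1 gives 52200 nM. Compound 2 `Cc1ccccc1OCC(=O)Nc1nc(-c2ccc(Br)cc2)cs1` differs from compound 1 by methyl in place of hydrogen on an aromatic carbon; in this assay compound 2 gives 49800 nM, so that a 1.0-fold lower number from compound 1 to compound 2 (0.02 log units; within the scatter). Compound 3 `O=C(COc1ccccc1)Nc1nc(-c2ccc(Cl)cc2)cs1` differs from compound 1 by chloro in place of bromo on an aromatic carbon; in this assay compound 3 gives 42800 nM, with a 1.2-fold lower number from compound 1 to compound 3 (0.09 log units; within the scatter). All three numbers sit close together, and no ranking among the three is drawn from them.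

Compound 4 `Cc1ccccc1OCC(=O)Nc1nc(-c2ccc(Cl)cc2)cs1` has not yet been run in this assay. It differs from compound 3 by methyl in place of hydrogen on an aromatic carbon, the same change as that from compound 1 to compound 2, the place being described in identical words for both pairs. The cores of compound 3 and compound 1 differ by chloro in place of bromo on an aromatic carbon. Within the data shown here, on the one measured instance of this change, a 1.0-fold lower number from compound 1 to compound 2 (0.02 log units; within the scatter), the expected step in this assay is a 1.0-fold lower number from compound 3 to compound 4 (0.02 log units; within the scatter), resting on compound 3 at 42800 nM and on that earlier step lying within the scatter. Compound 4 is therefore estimated at 41000 nM in this assay. For compound 4 the expected range is estimated to run from 25000 nM to 70000 nM, set wide since a single measured pair is a thin basis.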

Compound 4, half-maximal inhibitory concentration: 64800 nM
The estimate for compound 4 lay 1.6-fold (0.20 log units) below the measured number, and the stated range covers the measured number.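

In this assay, the change from phenoxy to 2-methylphenoxy gives a 1.5-fold higher number from compound 3 to compound 4 (0.18 log units; within the scatter), and the bromo and chloro cores show no measurable difference in how they take it: the same change on two cores in this assay, a 1.0-fold lower number (0.02 log units; within the scatter) from compound 1 to compound 2 and a 1.5-fold higher number (0.18 log units; within the scatter) from compound 3 to compound 4, 1.6-fold (0.20 log units) apart, within the scatter of two such steps

Chloro in place of bromo reads the same way, here with a 1.3-fold higher number from compound 2 to compound 4 (0.11 log units; within the scatter), and it too carries from the phenoxy compounds to the 2-methylphenoxy compounds without a measurable difference: the same change on two cores in this assay, a 1.2-fold lower number (0.09 log units; within the scatter) from compound 1 to compound 3 and a 1.3-fold higher number (0.11 log units; within the scatter) from compound 2 to compound 4, 1.6-fold (0.20 log units) apart, within the scatter of two such steps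

This shows that, in these four compounds, each change stays within the scatter on both cores; it does not show that a change with a real effect would carry from one core to another, since every step here is too small to test that, and two instances of each change are a thin basis.

The compounds shown hold only hydrogen or methyl on the phenoxy group and only bromo or chloro on the other aryl group, so it stays open whether an amine, a carboxylic acid or a methoxy group in those places would give a step beyond the scatter. Also open, on these data alone, is whether a longer chain in place of the link between the phenoxy group and the amide carbonyl would move the number, and whether any such step would then carry between the bromo and chloro cores.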